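This account rests on a few compounds, and the source may have more. Where it says the series, first, only, none or still open, it means among the compounds named here.

Measured so far in an ADME assay on Vero 76 cells (Chlorocebus sabaeus) for cytotoxicity, read by MTT assay, with a stated time of 96 h; on this read-out lower numbers stand for higher toxicity in this test and higher numbers for lower toxicity in this test:
Compound 1 `FC(F)(F)c1ccc(-c2nn(-c3ccccc3)cc2CNc2ccc(Cl)cc2)cc1` gives 10000 nM
Compound 2 `FC(F)(F)c1ccc(NCc2cn(-c3ccccc3)nc2-c2ccc(Cl)cc2)cc1` gives 18000 nM
Compound 3 `Clc1ccc(NCc2cn(-c3ccccc3)nc2-c2ccc(Cl)cc2)cc1` gives 90000 nM

Compound 3 has the highest number of the three at 90000 nM and lies beyond the scatter of both compound 1 and compound 2. Compound 4 `Cc1ccc(-c2nn(-c3ccccc3)cc2CNc2ccc(Cl)cc2)cc1` differs from compound 3 by a single exchange (methyl in place of chloro on an aromatic carbon) that turns 4-chlorophenyl into 4-methylphenyl.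

Among the measured compounds shown here, no measured compound carries this methyl, so no step shows the exchange directly. The nearest evidence is two modest steps, each with chloro in place of trifluoromethyl (a 9.0-fold higher number from compound 1 to compound 3 (0.95 log units; beyond the scatter)) and (a 5.0-fold higher number from compound 2 to compound 3 (0.70 log units; beyond the scatter)). Only the first falls on the aromatic carbon that changes in compound 4. Both end at compound 3, and each replacement of one of its chloro groups so far gave a lower number. A small step to a lower number is therefore expected, smaller than those two and possibly within the scatter. The expected change is a 1.8-fold lower number from compound 3 to compound 4 (0.26 log units; within the scatter) on this reasoning. In this assay compound 4 is estimated at 50000 nM (expected range 20000 nM to 100000 nM).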

Compound 4, half-maximal cytotoxic concentration: > 100000 nM
Compound 4: only a limit was reported; the forecaster's own chance of this, stated with the estimate: 20%; middle value at least 2.0-fold (0.30 log units) from the limit.
By their numbers in this assay, from the lowest: compounds 1 and 2 (each within the scatter of the next); then compound 3. At a limit, above all of these: compound 4.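

In this assay compound 4 gives only a limit and not a number: the limit of > 100000 nM in this assay, at which 1 of the 4 values shown sits. On this aromatic carbon, methyl in place of trifluoromethyl gives an at least 10-fold higher number from compound 1 to compound 4 (1.00 log units; beyond the scatter), so the high number of compound 3 does not depend on chloro at this position, and methyl serves there as well. Methyl in place of chloro gives an at least 1.1-fold higher number from compound 3 to compound 4 (0.04 log units; that floor lies within the scatter), the first exchange of a chloro group here that shows no lower number, although compound 3 and compound 4 cannot be told apart by this floor, which lies within the scatter.

As far as these compounds go, how far compound 4 really lies beyond compound 3 stays unknown while its reading is a limit. Also open, from the compounds shown here alone, is whether a hydroxy group, an amine or a carboxylic acid on this carbon would keep the number this high.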